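A few compounds are considered here, and "the series" means these few. Any claim that something is new, unique, unknown or untested is made for them only; others in the source may bear on it.

Measured so far in a functional assay on LS174T cells (Homo sapiens) for inhibition, with a stated time of 4 days, tested at 10 uM; a higher number here means a stronger effect of the compound at the concentration tested, a lower number a weaker effect:

Compound 1, `Fc1cccc(F)c1C#Cc1ccc2[nH]ccc2c1`, gives 91.5%.
Compound 2, `Cn1ccc2cc(C#Cc3c(F)cccc3F)ccc21`, gives 95.2%.
Compound 3, `Fc1cccc(F)c1C#Cc1ccc2[nH]ncc2c1`, gives 82.9%.

Compound 1 and compound 2 differ in one place: methyl in place of hydrogen on an aromatic nitrogen. That change made a step of a number 3.7 percentage points higher from compound 1 to compound 2 (within the scatter), so the two values sit within the usual scatter of each other and no order between them can be read. Compound 3 has a different core; the difference between the two cores is not broken down here. Compound 4, `Cn1ncc2cc(C#Cc3c(F)cccc3F)ccc21`, has not yet been measured in this assay. It differs from compound 3 by methyl in place of hydrogen on an aromatic nitrogen. This is the same kind of change as that from compound 1 to compound 2, though not the same: here the methyl enters on a five-membered aromatic ring with 2 nitrogen, next to the ring nitrogen, whereas in compound 1 that ring holds 1 nitrogen. Resting on the earlier step of a number 3.7 percentage points higher from compound 1 to compound 2 (within the scatter), the step from compound 3 to compound 4 is expected to be small, about a number 3.6 percentage points higher from compound 3 to compound 4 (within the scatter). Compound 4 is therefore estimated to give about 86.5%, most likely between 75% and 95%.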

Compound 4, a percentage reported as inhibition, at one concentration (the size of the read-out at that concentration, not a potency): 94.6%
Beside the measured number, compound 4's estimate is 8.1 percentage points below it, within the range that was stated.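

In this assay, methyl in place of hydrogen on an aromatic nitrogen now gives a step of a number 11.7 percentage points higher from compound 3 to compound 4 (beyond the scatter), so on this core the change has a real effect on the read-out, whereas on the core of compound 1 its effect could not be told from scatter. Even so, the two steps themselves cannot be told apart, so the data give no firm sign that the core alters what the methyl does: the same change on two cores in this assay, a number 3.7 percentage points higher (within the scatter) from compound 1 to compound 2 and a number 11.7 percentage points higher (beyond the scatter) from compound 3 to compound 4, 8 percentage points apart, within the scatter of two such steps This does not prove that the steps are equal, and two cores are too few to show how the change would behave on a third core.

The compounds shown carry only hydrogen or methyl on that aromatic nitrogen, which leaves open what a longer chain, such as ethyl, or a chain ending in an amine would do there. As far as these compounds go, each number also comes from a single tested concentration, so it tells only of a stronger or weaker effect at that concentration, and how the compounds would compare at other concentrations remains open.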